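Aryl swaps at the saturated ring carbon of the core

This account rests on a few compounds, and the source may have more. Where it says the series, first, only, none or still open, it means among the compounds named here.

Compound 1 `COc1ccc(C2OC(c3ccc4ccccc4c3)=NN2C(C)=O)cc1` gives 3.6 ug/mL in a functional assay on HepG2 cells (Homo sapiens) for antiproliferative activity, read by MTT assay, with a stated time of 48 h (a higher number here means a weaker inhibitor, a lower number a stronger inhibitor), the highest of the three numbers shown, though both other compounds lie within the scatter of it: compound 2 `CC(=O)N1N=C(c2ccc3ccccc3c2)OC1c1ccccc1F` gives 3.36 ug/mL and compound 3 `CC(=O)N1N=C(c2ccc3ccccc3c2)OC1c1ccccc1O` gives 1.84 ug/mL. The step of a 1.1-fold lower number from compound 1 to compound 2 (0.03 log units; within the scatter) and the step of a 2.0-fold lower number from compound 1 to compound 3 (0.29 log units; within the scatter) each exchange the aryl group on the saturated ring carbon without a change beyond the scatter, and the step of a 1.8-fold lower number from compound 2 to compound 3 (0.26 log units; within the scatter) is likewise within it. Compound 4 `CC(=O)N1N=C(c2ccc3ccccc3c2)OC1c1ccccn1` differs from compound 1 in one place: pyridin-2-yl in place of 4-methoxyphenyl on a saturated ring carbon. The two measured swaps at this position bear on it, and neither moved the number beyond the scatter, so no step beyond the scatter is expected in this assay. Compound 4 is therefore estimated at 3.2 ug/mL with a range from 1.3 ug/mL to 8 ug/mL, which means an expected step of a 1.1-fold lower number from compound 1 to compound 4 (0.05 log units; within the scatter).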

Compound 4, half-maximal inhibitory concentration: 5.26 ug/mL
Beside the measured number, compound 4's estimate is 1.6-fold (0.22 log units) below it; the measured number falls inside the stated range.
By their numbers in this assay, from the lowest: compounds 3, 2, 1 and 4 (each within the scatter of the next, the first and the last beyond it).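

In this assay, this position now shows a step beyond the scatter, though a modest one (a 2.9-fold higher number from compound 3 to compound 4 (0.46 log units; beyond the scatter)), and it separates pyridin-2-yl from 2-hydroxyphenyl only. Pyridin-2-yl stays within the scatter of the other two aryl groups (a 1.5-fold higher number from compound 1 to compound 4 (0.16 log units; within the scatter); a 1.6-fold higher number from compound 2 to compound 4 (0.19 log units; within the scatter)), so the series does not yet separate these three groups at this position. Open, as far as these compounds go, is whether a carboxylic acid or an amine on the aryl ring, or a longer chain in its place, would move the number further. For the compounds shown here, nothing available explains the one step beyond the scatter.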